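The source may hold more compounds than are shown below. What is called first, only, known or untested is meant among the compounds shown, and "the series" means these compounds.

Working notes on the series. Compound 3 `CN(c1ccc2cc(NC(=O)CCc3ccc(C(F)(F)F)cc3)ccc2n1)C1CCCC1` is the point of departure. In a functional assay on HEK293 cells for activation of melanin-concentrating hormone receptor 1 (Rattus norvegicus), read by inositol phosphate accumulation (a higher number here means that more compound is needed for the effect, a lower number that less compound is needed), compound 3 gives 350 nM, which stands second highest of the three numbers. Compound 2 `CC1CCCN1c1ccc2cc(NC(=O)CCc3ccc(C(F)(F)F)cc3)ccc2n1` gives 270 nM in this assay, and a 1.3-fold higher number from compound 2 to compound 3 (0.11 log units; within the scatter). Compound 1 `O=C(CCc1ccc(C(F)(F)F)cc1)Nc1ccc2nc(N3CC4CC3CN4)ccc2c1` gives 490 nM in this assay, and a 1.4-fold lower number from compound 1 to compound 3 (0.15 log units; within the scatter). All three values lie within the scatter of one another, so no order can be read among them.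

Within the data shown here, compound 4 `O=C(CCc1ccc(C(F)(F)F)cc1)Nc1ccc2nc(N3CC4CC3CO4)ccc2c1` has not yet been measured. a group of 7 heavy atoms (5 carbon, 1 nitrogen, 1 oxygen; 2 five-membered non-aromatic rings with 1 hetero atom each) in place of a group of 7 heavy atoms (6 carbon, 1 nitrogen; one five-membered non-aromatic ring of carbon only), on an aromatic carbon The step that bears on this change is the one from compound 1 to compound 3, since the group on compound 1 likewise holds 2 five-membered non-aromatic rings with 1 hetero atom each; that step was a 1.4-fold lower number from compound 1 to compound 3 (0.15 log units; within the scatter). The step of a 1.8-fold lower number from compound 1 to compound 2 (0.26 log units; within the scatter) was also within the scatter. The change a 1.3-fold higher number from compound 3 to compound 4 (0.11 log units; within the scatter) is therefore expected to stay within the scatter of this assay. Compound 4 is expected to give 450 nM, in the range 200 nM to 1100 nM.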

Compound 4, half-maximal effective concentration: 70 nM
Compound 4: the middle estimate sits 6.4-fold (0.81 log units) above what was measured, outside the stated range (below it).
By their numbers in this assay, from the lowest: compound 4; then compounds 2, 3 and 1 (each within the scatter of the next).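

The position on the aromatic carbon next to the ring nitrogen, which had shown no separation among the first three groups, does respond to the group placed there (a 5.0-fold lower number from compound 3 to compound 4 (0.70 log units; beyond the scatter); a 3.9-fold lower number from compound 2 to compound 4 (0.59 log units; beyond the scatter)) in this assay. Among these compounds, the closest comparison is the one in which both groups have 7 heavy atoms and 2 five-membered non-aromatic rings, with one ring nitrogen replaced by oxygen (a 7.0-fold lower number from compound 1 to compound 4 (0.85 log units; beyond the scatter)); compound 1 thus shows that this two-ring frame does not by itself go with a lower number. Nothing measured here explains this step.

The compounds shown leave open whether the oxygen needs the two-ring frame at all. Morpholin-4-yl, or a sulfur atom in place of the oxygen in the same frame, would separate the contribution of the atom from that of the frame.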